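A few compounds are considered here, and "the series" means these few. Any claim that something is new, unique, unknown or untested is made for them only; others in the source may bear on it.

In a toxicity assay on HEK293 cells (Homo sapiens) for inhibition, read by resazurin assay, with a stated time of 24 h (a lower number here means that less compound is tolerated, a higher number that more compound is tolerated), compound 1 `O=C(c1ncc([N+](=O)[O-])[nH]1)N1CCCC1` gives > 100000 nM, which is a limit of the assay and not a number. Compound 2 `O=C(NC1CC1)c1ncc([N+](=O)[O-])[nH]1` gives > 100000 nM, which is likewise a limit. Compound 2 therefore stands only on (the limit of > 100000 nM in this assay, at which 2 of the 2 values shown sit), with no number to place it more exactly. Compound 3 `NC(=O)c1ncc([N+](=O)[O-])[nH]1` departs from it by one change, (hydrogen in place of cyclopropyl on an amide-type nitrogen), that is, hydrogen in place of cyclopropyl on an amide-type nitrogen. Among the compounds with values here, the only measured step that bears on this change is a step that the two limits leave unreadable from compound 1 to compound 2, which also alters the group on the amide-type nitrogen but offers no size to carry over. No shift beyond the scatter is therefore expected in this assay. The expected step is a number no higher from compound 2 to compound 3 (the limit leaves the size open). Compound 3 is estimated to give 100000 nM, with an expected range from 50000 nM to 200000 nM.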

Compound 3, half-maximal cytotoxic concentration: > 100000 nM
Compound 3 ended at the assay's limit (the forecaster's own chance of this, stated with the estimate: 85%); the middle value sits exactly at the limit.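

No step can be read among compound 1, compound 2 and compound 3 in this assay, as each value is a limit of the assay and not a number: the limit of > 100000 nM in this assay, at which 3 of the 3 values shown sit.

The compounds shown leave open at what concentration any of them would become toxic to these cells, and whether pyrrolidin-1-yl, cyclopropylamino and amino differ at all in this respect.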